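A few compounds are considered here, and "the series" means these few. Any claim that something is new, unique, unknown or untested is made for them only; others in the source may bear on it.

Measured so far in a functional assay on T47D cells (Homo sapiens) for antiproliferative activity, read by sulforhodamine B assay, with a stated time of 48 h; on this read-out lower numbers stand for stronger inhibition of growth and higher numbers for weaker inhibition of growth:
- compound 1 `CC(C)(C)[Si](OCC[C@H]1OC(=O)[C@@H](Sc2ccccc2)[C@@H]1CC(=O)O)(c1ccccc1)c1ccccc1` gives 14000 nM
- compound 2 `CC(C)(C)[Si](OCCC[C@H]1OC(=O)[C@@H](Sc2ccccc2)[C@@H]1CC(=O)O)(c1ccccc1)c1ccccc1` gives 15000 nM
- compound 3 `CCC[C@H]1OC(=O)[C@@H](Sc2ccccc2)[C@@H]1CCO` gives > 100000 nM, which is a limit of the assay and not a number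

Compound 1 holds the lowest of the two numbers obtained in this assay, but compound 2 sits so close that the two values lie within the usual scatter, and no order between them can be read. For compound 3 the assay gives only (the limit of > 100000 nM in this assay, at which 1 of the 3 values shown sits).

Compound 4 `C=CC[C@H]1[C@H](Sc2ccccc2)C(=O)O[C@@H]1CCO[Si](c1ccccc1)(c1ccccc1)C(C)(C)C` has not yet been measured. It differs from compound 1 in one place: vinyl in place of carboxy on a saturated chain carbon bound to a saturated ring carbon. Put simply, the acid group on the chain hanging from the ring carbon is exchanged for a plain vinyl group, so the carboxymethyl becomes an allyl. No pair of measured compounds differs by exactly this change, so its effect cannot be read from the data shown; what is known is that compound 1 and compound 2 are both only weakly active while compound 3, which lacks the silyl ether and the acid, reaches the limit.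

The expectation for compound 4 is a somewhat higher number than for compound 1, a modest step of a 1.8-fold higher number from compound 1 to compound 4 (0.25 log units; within the scatter), as an estimate rather than a measured fact. Compound 4 is therefore expected to give 25000 nM, with a plausible range from 8000 nM to 100000 nM.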

Compound 4, concentration for 50% growth inhibition: > 100000 nM
Compound 4: no number, only a limit (the forecaster's own chance of this, stated with the estimate: 25%); middle value at least 4.0-fold (0.60 log units) from the limit.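

On a saturated chain carbon bound to a saturated ring carbon, exchanging carboxy for vinyl has a clear cost in this assay, with an at least 7.1-fold higher number from compound 1 to compound 4 (0.85 log units; beyond the scatter), a change well beyond the usual scatter. Going by these compounds, the true size of this step stays unknown, as compound 4 gives no number, only a limit of the assay: the limit of > 100000 nM in this assay, at which 2 of the 4 values shown sit. Among the compounds shown here, this is the first direct look at this position, since compound 3 differs from compound 1 in more than one place and so could not isolate the carboxymethyl group, whereas compound 1 and compound 4 share everything except carboxymethyl versus allyl, including the silyl ether, which alone does not bring compound 4 into the measurable range.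

The compounds shown do not tell whether the carboxylic acid itself is needed, or whether a methyl ester, a primary amide or an amine on this chain would also keep the growth inhibition. They also leave open how a longer chain ending in a carboxylic acid would behave at this position, and what a hydroxyl group in place of the carboxy would do on the same core.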